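Hydroxy for amino on two isomeric cores

A few compounds are considered here, and "the series" means these few. Any claim that something is new, unique, unknown or untested is made for them only; others in the source may bear on it.

Two cores carry the same pair of aromatic substituents. Compound 1 `C=C1[C@@H](O)[C@H](n2cnc3c(N)ncnc32)O[C@@H]1CO` gives 43000 nM in a functional assay on MT4 cells (Homo sapiens) for inhibition; a lower number here means a stronger inhibitor, a higher number a weaker inhibitor. Compound 2 `C=C1[C@@H](O)[C@H](n2cnc3c(O)ncnc32)O[C@@H]1CO` carries hydroxy in place of amino on an aromatic carbon on that core, and in this assay compound 2 reaches only the limit > 200000 nM, not a number. The step of an at least 4.6-fold higher number from compound 1 to compound 2 (0.66 log units; beyond the scatter) is therefore a lower bound on the loss, because compound 2 sits at the limit of > 200000 nM in this assay, at which 1 of the 3 values shown sits. Compound 3 `C=C1[C@H](n2cnc3c(N)ncnc32)O[C@H](CO)[C@H]1O` is built from the same atoms as compound 1, joined differently; the difference between the two cores is not broken down here. In this assay, among the measured compounds shown here, compound 3 gives 131000 nM, the higher of the two numbers measured so far. Compound 4 `C=C1[C@H](n2cnc3c(O)ncnc32)O[C@H](CO)[C@H]1O` is compound 3 with the same change, (hydroxy in place of amino on an aromatic carbon), the place being described in identical words for both pairs. Since compound 3 already stands above compound 1, the expected step of a 4.6-fold higher number from compound 3 to compound 4 (0.66 log units; beyond the scatter) would carry it past the limit if the loss resembles an at least 4.6-fold higher number from compound 1 to compound 2 (0.66 log units; beyond the scatter). For compound 4 the estimated value is 600000 nM, expected between 250000 nM and 2000000 nM, most likely reported as a limit rather than a number.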

Compound 4, half-maximal inhibitory concentration: > 200000 nM
Compound 4 was reported as a limit; the forecaster's own chance of this, stated with the estimate: 85%; the middle value lies beyond the limit too.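

In this assay compound 4 is reported only as a limit, > 200000 nM, not as a number. On this core the change can therefore be read only as a floor, an at least 1.5-fold higher number from compound 3 to compound 4 (0.18 log units; that floor lies within the scatter), which shows no gain from hydroxy in place of amino but does not by itself establish a loss. Across the two cores the direction of the change is compatible, while its size cannot be said to carry over from one core to the other: the same change on two cores in this assay, an at least 4.6-fold higher number (0.66 log units; beyond the scatter) from compound 1 to compound 2 and an at least 1.5-fold higher number (0.18 log units; that floor lies within the scatter) from compound 3 to compound 4; the limit leaves it open whether they differ

Going by these compounds, how compound 2 and compound 4 compare remains open, as both stop at the same point: the limit of > 200000 nM in this assay, at which 2 of the 4 values shown sit. Also open is whether another group on that aromatic carbon, such as methylamino, methoxy or chloro, would keep or improve on the values of the amino compounds, and whether the order of the two cores would hold with such a group.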